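This account rests on a few compounds, and the source may have more. Where it says the series, first, only, none or still open, it means among the compounds named here.

Compound 1 `Cc1nc(-c2ccccc2F)sc1COc1ccc2c(c1)OCC2CC(=O)O` — 25.8%
Compound 2 `Cc1nc(-c2cccc(F)c2)sc1COc1ccc2c(c1)OCC2CC(=O)O` — 56.9%

Of the compounds shown here, two have so far been tested in a functional assay on CHO cells for agonist activity at Free fatty acid receptor 1 (Homo sapiens), read by FLIPR and calcium flux, tested at 100 nM; a higher number here means a stronger effect of the compound at the concentration tested, a lower number a weaker effect. Compound 1 gives 25.8% in this assay, while compound 2 gives 56.9% in this assay. Among the compounds with values here, of these two numbers compound 2 stands highest, and the single measured step, a number 31.1 percentage points higher from compound 1 to compound 2 (beyond the scatter), shows that swapping one fluorophenyl for another on the shared core can shift the read-out by a large amount.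

Compound 3 `COc1cc(OC)cc(-c2nc(C)c(COc3ccc4c(c3)OCC4CC(=O)O)s2)c1` has not yet been measured. It differs from compound 2 in 3,5-dimethoxyphenyl in place of 3-fluorophenyl on an aromatic carbon. Within the data shown here, the only measured step bears on this change just loosely: it concerns two fluorophenyl groups at the same place, not a 3,5-dimethoxyphenyl, so it cannot say in which direction the new group will move the number. It does show that this place is sensitive, so a step beyond the scatter in this assay is plausible either way. With no closer guide, compound 3 is expected to give 40% in this assay, with a wide range from 10% to 75%, which means an estimated step of a number 16.9 percentage points lower from compound 2 to compound 3 (beyond the scatter).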

Compound 3, a percentage reported as activity, at one concentration (the size of the read-out at that concentration, not a potency): 17.5%
The estimate for compound 3 lay 22.5 percentage points above the measured number, within the range that was stated.
By their numbers in this assay, from the lowest: compounds 3 and 1 (each within the scatter of the next); then compound 2.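

In this assay, the new result shows that this place on the thiazole-free reading of the shared core responds not only to where a fluorine sits but also to a quite different aryl group: putting 3,5-dimethoxyphenyl in place of 3-fluorophenyl gives a number 39.4 percentage points lower from compound 2 to compound 3 (beyond the scatter). The other new step, a number 8.3 percentage points lower from compound 1 to compound 3 (within the scatter), means that 3,5-dimethoxyphenyl and 2-fluorophenyl cannot be told apart here, so among the three groups seen so far only 3-fluorophenyl stands clear of the others, and two very different groups can end up at the same level. Nothing available explains this difference between the three compounds.

Compound 3 swaps the fluorine for methoxy groups and also puts two groups on the ring instead of one, so the compounds shown cannot say which of these two changes goes with the lower number. A plain phenyl ring or a phenyl carrying a single methoxy group would help to separate them, and a chlorine or a nitrile on the ring would show how special the fluorine of compound 2 really is.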